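Trifluoromethoxy for Trifluoromethyl, Tried on a Second Core

This account rests on a few compounds, and the source may have more. Where it says the series, first, only, none or still open, it means among the compounds named here.

Compound 1 `Cn1nnnc1NC(=O)N1CCC2(CC1)CC(c1cccc(C(F)(F)F)c1)C2` was examined in a functional assay on the whole organism for inhibition, with Rattus norvegicus as the target, with a stated time of 3 h, at a dose of 3 mg/kg by the oral route (on this read-out higher numbers stand for an effect only at larger amounts of compound and lower numbers for an effect already at smaller amounts), where compound 1 gives 1 mg/kg. Compound 2 `Cn1nnnc1NC(=O)N1CCC2(CC1)CC(c1cccc(OC(F)(F)F)c1)C2` differs from compound 1 in a single spot: trifluoromethoxy in place of trifluoromethyl on an aromatic carbon. In this assay compound 2 gives 0.1 mg/kg. That one exchange produced a 10-fold lower number from compound 1 to compound 2 (1.00 log units; beyond the scatter).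

Compound 3 `Cn1nnnc1NC(=O)N1CCC2(CC1)CC(c1cccc(C(F)(F)F)c1)CO2` is built on a different core; how the two cores differ is not broken down here. In this assay compound 3 gives 1 mg/kg, level with compound 1 at the digits shown and within the usual scatter of it. Compound 4 `Cn1nnnc1NC(=O)N1CCC2(CC1)CC(c1cccc(OC(F)(F)F)c1)CO2` has not yet been measured. It differs from compound 3 by trifluoromethoxy in place of trifluoromethyl on an aromatic carbon, the same change that turned compound 1 into compound 2, and the surroundings of the place are described in identical words in both pairs. Among the compounds shown this change appears in two pairs in all.

Among the measured compounds shown here, the step from compound 3 to compound 4 is expected to be a 10-fold lower number from compound 3 to compound 4 (1.00 log units; beyond the scatter), resting on the single earlier instance, a 10-fold lower number from compound 1 to compound 2 (1.00 log units; beyond the scatter). That precedent is the only one, and it was seen on another core. The expectation therefore carries a wide margin. For compound 4 the estimated result in this assay is 0.1 mg/kg, with a range from 0.03 mg/kg to 1 mg/kg.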

Compound 4, minimum effective dose: 0.1 mg/kg
The estimate for compound 4 equals the measured number at the digits printed; the measured number falls inside the stated range.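

In this assay, putting trifluoromethoxy in place of trifluoromethyl on the second core gave a 10-fold lower number from compound 3 to compound 4 (1.00 log units; beyond the scatter), so the exchange that helped on the core of compound 1 also helped on the core of compound 3. Set side by side, the two steps match, and the size of the change did not depend on which of these cores carried it: the same change on two cores in this assay, a 10-fold lower number (1.00 log units; beyond the scatter) from compound 1 to compound 2 and a 10-fold lower number (1.00 log units; beyond the scatter) from compound 3 to compound 4, 1.0-fold (0.00 log units) apart, within the scatter of two such steps This is still only a pair of examples from one whole-animal read-out, so it supports carrying the exchange between these cores but shows neither that it would hold on a further core nor why the lower number appears.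

The compounds shown hold only trifluoromethyl and trifluoromethoxy at this place on the aromatic ring, so it remains open whether a smaller or differently built group, such as a chlorine atom, a nitrile or a plain methoxy group, would give a result like that of trifluoromethoxy or of trifluoromethyl. As far as these compounds go, it also remains open how the exchange would behave on a core carrying an amine or a carboxylic acid, since every compound here keeps the same remaining framework.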